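Adding a Hydroxy Group to the Fused Ring of Compound 2

The compounds below may be only part of what the source reports. "The series", "measured", "known", "first", "only" and "open" are said of these compounds alone.

Compound 1 `CN(C)c1ccc(-c2ccc(-c3ccc(-c4nc5ccccc5[nH]4)cc3)cc2)cc1` gives 100000 nM in a functional assay on DWD cells (Homo sapiens) for inhibition, read by sulforhodamine B assay; on this read-out lower numbers stand for stronger inhibition of growth and higher numbers for weaker inhibition of growth.
Compound 2 `COc1ccc(-c2ccc(-c3ccc(-c4nc5ccccc5[nH]4)cc3)cc2)cc1OC` gives 42100 nM in this assay.
Compound 3 `COc1cc(-c2ccc(-c3ccc(-c4nc5ccccc5[nH]4)cc3)cc2)cc(OC)c1OC` gives 8010 nM in this assay.

Among these three numbers compound 2 stands second highest: compound 1 sits above it and compound 3 below it, both beyond the scatter. Compound 4 `COc1ccc(-c2ccc(-c3ccc(-c4nc5c(O)cccc5[nH]4)cc3)cc2)cc1OC` differs from compound 2 in one place: hydroxy in place of hydrogen on an aromatic carbon. The two steps measured so far, a 2.4-fold lower number from compound 1 to compound 2 (0.38 log units; beyond the scatter) and a 5.3-fold lower number from compound 2 to compound 3 (0.72 log units; beyond the scatter), both change the aryl ring at the far end of the shared core, not the fused two-ring system, so neither bears directly on this change. Among the compounds with values here, with no comparable step available, the step expected here, a 1.2-fold lower number from compound 2 to compound 4 (0.08 log units; within the scatter), is none beyond the scatter. Compound 4 is therefore estimated at 35000 nM, within a range from 10000 nM to 100000 nM.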

Compound 4, concentration for 50% growth inhibition: 1400 nM
The estimate for compound 4 lay 25-fold (1.40 log units) above the measured number; measured number below the stated range.
By their numbers in this assay, from the lowest: compound 4; then compound 3; then compound 2; then compound 1.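

In this assay, the fused ring turns out to be a sensitive place: 4-hydroxy-1H-benzimidazol-2-yl in place of 1H-benzimidazol-2-yl gives a 30-fold lower number from compound 2 to compound 4 (1.48 log units; beyond the scatter) and is a large step, whereas both earlier steps, made at the far end of the shared core, were modest. So one small group on this ring changes the number more than either of those aryl changes. Nothing measured here explains why this hydroxy has such an effect. On these data alone, whether the same position would respond similarly to a methoxy or an amine remains open. Also open, as far as these compounds go, is whether the hydroxy would give a similar step on the core of compound 3.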